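A few compounds are considered here, and "the series" means these few. Any claim that something is new, unique, unknown or untested is made for them only; others in the source may bear on it.

Within the data shown here, compound 2 `C(=N/N(Cc1ccccc1)Cc1ccccc1)\c1cccnc1` holds the only number measured in an assay on liver (Sus scrofa) for inhibition of glucose-6-phosphatase catalytic subunit 1 (Homo sapiens), using microsomes (on this read-out higher numbers stand for weaker inhibition and lower numbers for stronger inhibition), giving 3700 nM. Compound 1 `Clc1cc(Cl)cc(/C=N/N(Cc2ccccc2)Cc2ccccc2)c1` reached only a limit of this assay, > 100000 nM. Among the measured compounds shown here, the one measured step, an at least 27-fold lower number from compound 1 to compound 2 (1.43 log units; beyond the scatter), can only be given as a minimum because compound 1 sits at the limit of > 100000 nM in this assay, at which 1 of the 2 values shown sits. Compound 3 `CCc1ccc(/C=N/N(Cc2ccccc2)Cc2ccccc2)o1` differs from compound 2 by 5-ethylfuran-2-yl in place of pyridin-3-yl on a carbon with a double bond to nitrogen. That measured step concerned a different exchange, so it gives no direction for this one; a change of modest size is expected, a 1.4-fold higher number from compound 2 to compound 3 (0.13 log units; within the scatter), and compound 3 is estimated at 5000 nM, between 1500 nM and 20000 nM.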

Compound 3, half-maximal inhibitory concentration: 330 nM
Compound 3: the middle estimate sits 15-fold (1.18 log units) above what was measured, and the stated range ends above it.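

At this place, on a carbon with a double bond to nitrogen, a five-membered aromatic ring does better than the six-membered pyridin-3-yl: in this assay, 5-ethylfuran-2-yl gives an 11-fold lower number from compound 2 to compound 3 (1.05 log units; beyond the scatter). Across the three groups shown, the exchange reaches further still, with an at least 300-fold lower number from compound 1 to compound 3 (2.48 log units; beyond the scatter). That step is only a minimum because compound 1 sits at a limit: the limit of > 100000 nM in this assay, at which 1 of the 3 values shown sits.

Going by these compounds, since 5-ethylfuran-2-yl brings a new ring and an ethyl chain together, the share of each remains open. A plain furan-2-yl, or a longer chain in place of the ethyl, would begin to separate them.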